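A few compounds are considered here, and "the series" means these few. Any claim that something is new, unique, unknown or untested is made for them only; others in the source may bear on it.

Working notes on the series, read in a functional assay for inhibition, with Sus scrofa as the target; a higher number here means a weaker inhibitor, a lower number a stronger inhibitor. Going by the values given here, compound 1 (`CC1(C)Oc2ccc(C#N)cc2[C@@H](Oc2ccccn2)[C@]1(C)O`) gives 6000 nM, the higher of the two numeric values so far. Compound 3 (`CC1(C)Oc2ccc(C#N)cc2[C@@H](Oc2ccc(=O)[nH]n2)[C@@]1(O)CO`) gives 700 nM, a lower number by a gap beyond the scatter. Compound 2 (`CC1=C(N2CCCC2=O)c2cc(C#N)ccc2OC1(C)C`) reads > 100000 nM, which is a limit of the assay and not a number. Compound 4 (`CC1(C)Oc2ccc(C#N)cc2[C@@H](n2nc(N)ccc2=O)[C@]1(C)O`) is still unmeasured and differs from compound 1 as follows: a group of 8 heavy atoms (4 carbon, 3 nitrogen, 1 oxygen; one six-membered aromatic ring with 2 hetero atoms) in place of a group of 7 heavy atoms (5 carbon, 1 nitrogen, 1 oxygen; one six-membered aromatic ring with 1 hetero atom), on a saturated ring carbon. Among the compounds with values here, no measured step isolates this change. A move to a lower number, beyond the scatter, is expected, and this rests only on compound 3 at 700 nM. The estimated shift is a 3.0-fold lower number from compound 1 to compound 4 (0.48 log units; beyond the scatter). For compound 4 the expected value is 2000 nM, within an estimated range of 400 nM to 10000 nM.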

Compound 4, half-maximal inhibitory concentration: 40000 nM
For compound 4 the middle estimate is 20-fold (1.30 log units) below the measured one, and the stated range ends below it.
By their numbers in this assay, from the lowest: compound 3; then compound 1; then compound 4. At a limit, above all of these: compound 2.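

In this assay, going by these compounds alone, the first change at this position that can be read on its own goes towards weaker inhibition: replacing (pyridin-2-yl)oxy with the larger group gives a 6.7-fold higher number from compound 1 to compound 4 (0.82 log units; beyond the scatter) on this saturated ring carbon. This position therefore responds to the group it carries, and a ring with 2 hetero atoms brings no gain here. Nothing measured in the data shown accounts for this step.

The compounds shown leave open whether the linking atom or the ring itself carries the step. On these data alone, how a methoxy group or a carboxylic acid on the (pyridin-2-yl)oxy group would read also stays open.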